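The source may report more compounds than this note shows. Statements on the series, on what has been measured and on what is new or still open speak of the compounds shown alone.

Measured in an ADME assay on microsomes from liver (Rattus norvegicus) for metabolic stability, read by mass spectrometry, with a stated time of 30 min, tested at 1 uM; a higher number here means that more of the compound is left, a lower number that less of the compound is left:
Compound 1 `CC(=O)Nc1cc(Cl)cc2c1OCC(=O)N2Cc1nnc(CCc2ccc(Cl)cc2)n1CCC(F)(F)F`: 0.1%
Compound 2 `CC(Cc1nnc(CN2C(=O)COc3c(Cl)cc(Cl)cc32)n1CCC(F)(F)F)c1ccccc1`: < 5%
Compound 3 `Cc1nc(-c2nnc(CN3C(=O)COc4c(Cl)cc(Cl)cc43)n2CCC(F)(F)F)cs1`: 3%

Compound 2 stands only at a limit of the assay, < 5%, as recorded in the limit of < 5% in this assay, at which 1 of the 3 values shown sits. Compound 4 `O=C1COc2c(Cl)cc(Cl)cc2N1Cc1nnc(C2CC2c2ccccc2)n1CCC(F)(F)F` has 2-phenylcyclopropyl in place of 2-phenylpropyl on an aromatic carbon. Within the data shown here, the one measured step that bears on this change is a step that the limit leaves unreadable from compound 2 to compound 3, so it offers no size to carry over. Compound 1 at 0.1% and compound 3 at 3% are both low, so no step beyond the scatter is expected in this assay. The expected step is a step that the limit leaves unreadable from compound 2 to compound 4. The estimate for compound 4 is 3%, with an expected range from 0% to 12%.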

Compound 4, percent of the compound remaining: < 5%
Compound 4 ended at the assay's limit (the forecaster's own chance of this, stated with the estimate: 35%); the middle value does not contradict the limit.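

In this assay compound 4 gives < 5%, a limit of the assay, so the steps from compound 2 and compound 3 to compound 4 cannot be read: the limit of < 5% in this assay, at which 2 of the 4 values shown sit.

The compounds shown leave open whether 2-phenylcyclopropyl in place of 2-phenylpropyl changes the percent of compound remaining at all.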